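Ester Size Change on the Methyl Ester of Compound 1

This account rests on a few compounds, and the source may have more. Where it says the series, first, only, none or still open, it means among the compounds named here.

Compound 1 `COC(=O)c1cc(N2C(=O)C3=C(CCCC3)C2=O)ccc1Cl` is the weakest of the three measured compounds in a functional assay on the whole organism for inhibition, with Scenedesmus acutus as the target (on this read-out lower numbers stand for stronger inhibition and higher numbers for weaker inhibition), where compound 1 gives 1780 nM. Compound 2 `COC(=O)c1cc(N2C(=O)C3=C(CCCC3)C2=O)c(F)cc1Cl` gives 67.6 nM in this assay, and compound 3 `CC(C)COC(=O)c1cc(N2C(=O)C3=C(CCCC3)C2=O)c(F)cc1Cl` gives 100 nM. The step of a 26-fold lower number from compound 1 to compound 2 (1.42 log units; beyond the scatter) is large, while the step of a 1.5-fold higher number from compound 2 to compound 3 (0.17 log units; within the scatter) is small.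

Compound 4 `CC(C)(C)OC(=O)c1cc(N2C(=O)C3=C(CCCC3)C2=O)ccc1Cl` is not yet measured. The change from compound 1 to compound 4 is tert-butyl in place of methyl on an oxygen next to a carbonyl group, so the methoxycarbonyl group becomes a tert-butoxycarbonyl group. Within the data shown here, the only measured step that bears on this is the ester change from compound 2 to compound 3, where isopropyl entered on the saturated chain carbon bound to the ester oxygen and the number moved only within the scatter. A step of similar size is therefore expected here, with at most a slight weakening: compound 4 is estimated to give 2500 nM in this assay, within a range from 1000 nM to 6000 nM. This means an expected step of a 1.4-fold higher number from compound 1 to compound 4 (0.15 log units; within the scatter), not beyond the scatter.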

Compound 4, half-maximal inhibitory concentration: 81300 nM
Estimate against measurement, compound 4: 33-fold (1.51 log units) below; the measured number lies above the stated range.
By their numbers in this assay, from the lowest: compounds 2 and 3 (each within the scatter of the next); then compound 1; then compound 4.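

Replacing methyl with tert-butyl on the oxygen next to a carbonyl group gives a 46-fold higher number from compound 1 to compound 4 (1.66 log units; beyond the scatter) in this assay, so this position can respond strongly to the group placed on it. The earlier ester step, a 1.5-fold higher number from compound 2 to compound 3 (0.17 log units; within the scatter), therefore does not describe every ester change, although it involved a different change, isopropyl in place of hydrogen on the saturated chain carbon bound to that oxygen, and it was read on compounds carrying fluoro. Nothing available here accounts for the size of the new step.

Going by these compounds, whether tert-butyl would give a step of similar size with fluoro present remains open. So does the place of the ethyl ester, which lies in size between methyl and tert-butyl, or of the free carboxylic acid, on this scale of inhibition.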